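Carbamoyl for cyano, then naphthyl for tolyl in bis-benzimidazoles

The source may report more compounds than this note shows. Statements on the series, on what has been measured and on what is new or still open speak of the compounds shown alone.

Measured compounds:
Compound 1 `Cc1ccc(-c2nc3cc(-c4nc5cc(C#N)ccc5[nH]4)ccc3[nH]2)cc1`: 570 nM
Compound 2 `N#Cc1ccc2[nH]c(-c3ccc4[nH]c(-c5cccc6ccccc56)nc4c3)nc2c1`: 650 nM
Compound 3 `Cc1ccc(-c2nc3cc(-c4nc5cc(C(N)=O)ccc5[nH]4)ccc3[nH]2)cc1`: > 25000 nM

In a functional assay on RPMI 8402 cells (Homo sapiens) for cytotoxicity (on this read-out lower numbers stand for stronger inhibition and higher numbers for weaker inhibition), compound 1 gives 570 nM. Compound 2 differs from it by naphthalen-1-yl in place of 4-methylphenyl on an aromatic carbon, and the step is a 1.1-fold higher number from compound 1 to compound 2 (0.06 log units; within the scatter). Compound 3 carries a different core, set apart by carbamoyl in place of cyano on an aromatic carbon. Compound 3 reaches only a limit of this assay, > 25000 nM, so the step of an at least 43-fold higher number from compound 1 to compound 3 (1.64 log units; beyond the scatter) is known only as a lower bound, its value sitting at the limit of > 25000 nM in this assay, at which 1 of the 3 values shown sits.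

Compound 4 `NC(=O)c1ccc2[nH]c(-c3ccc4[nH]c(-c5cccc6ccccc56)nc4c3)nc2c1` is not yet measured. It is made from compound 3 by naphthalen-1-yl in place of 4-methylphenyl on an aromatic carbon, the same change as from compound 1 to compound 2. Because that earlier step was a 1.1-fold higher number from compound 1 to compound 2 (0.06 log units; within the scatter), the expected step that the limit leaves unreadable from compound 3 to compound 4 is likewise small. Compound 4 is therefore expected to give about 30000 nM in this assay, most likely again only as a limit.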

Compound 4, half-maximal inhibitory concentration: 3700 nM
Beside the measured number, compound 4's estimate is 8.1-fold (0.91 log units) above it; the whole stated range lies above it.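

In this assay, naphthalen-1-yl in place of 4-methylphenyl on the carbamoyl compounds gives an at least 6.7-fold lower number from compound 3 to compound 4 (0.82 log units; beyond the scatter), so this change does not carry over unaltered from the nitrile compounds: the same change on two cores in this assay, a 1.1-fold higher number (0.06 log units; within the scatter) from compound 1 to compound 2 and an at least 6.7-fold lower number (0.82 log units; beyond the scatter) from compound 3 to compound 4, at least 7.7-fold (0.88 log units) apart, beyond the scatter of two such steps. Seen the other way, carbamoyl in place of cyano still weakens the naphthalen-1-yl compounds, with a 5.7-fold higher number from compound 2 to compound 4 (0.76 log units; beyond the scatter), but by a different amount than on the 4-methylphenyl compounds: the same change on two cores in this assay, an at least 43-fold higher number (1.64 log units; beyond the scatter) from compound 1 to compound 3 and a 5.7-fold higher number (0.76 log units; beyond the scatter) from compound 2 to compound 4, at least 7.7-fold (0.88 log units) apart, beyond the scatter of two such steps. The value of compound 3 is a limit of the assay, so both gaps are lower bounds, and the four compounds do not show why the steps differ or whether this holds on other cores.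

The compounds shown leave open how a carboxylic acid or an amine in place of the carbamoyl would read. They also leave open whether naphthalen-2-yl would behave as naphthalen-1-yl does.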